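The compounds below may be only part of what the source reports. "The series", "measured", "known", "first", "only" and "open" are said of these compounds alone.

Compound 1: `COc1ccccc1Nc1nc(-c2cccc(F)c2)nc2ccc(F)cc12`. In a functional assay on COLO 205 cells (Homo sapiens) for cytotoxicity, read by MTT assay, with a stated time of 48 h (a higher number here means a weaker inhibitor, a lower number a stronger inhibitor), compound 1 gives > 50000 nM, which is a limit of the assay.
Compound 2: `Nc1ccc(Nc2nc(-c3cccc(F)c3)nc3ccc(F)cc23)cc1`. In this assay compound 2 gives > 50000 nM, again a limit of the assay and not a number.

Compound 2 therefore stands at the edge of what this assay can report, and it shares that position with compound 1, as the limit of > 50000 nM in this assay, at which 2 of the 2 values shown sit, shows. Among the measured compounds shown here, the only measured step, from compound 1 to compound 2, is a step that the two limits leave unreadable from compound 1 to compound 2, and it says nothing about size or direction.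

Compound 3 is `Nc1cccc(Nc2nc(-c3cccc(F)c3)nc3ccc(F)cc23)c1`. The change from compound 2 is 3-aminophenyl in place of 4-aminophenyl on a nitrogen on an aromatic ring; the two have the same atoms, joined differently. No readable step bears on it, so compound 3 is expected to stay at the limit, with a step of a number no higher from compound 2 to compound 3 (the limit leaves the size open) that is expected to be nothing beyond the scatter. Compound 3 is estimated at 50000 nM, in a range from 15000 nM to 150000 nM.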

Compound 3, half-maximal inhibitory concentration: > 50000 nM
Compound 3 ended at the assay's limit (the forecaster's own chance of this, stated with the estimate: 80%); the middle value lies on the limit itself.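

Compound 3 sits at the limit with compound 1 and compound 2, so neither step reaching compound 3 can be read, in size or direction: the limit of > 50000 nM in this assay, at which 3 of the 3 values shown sit.

The compounds shown leave open how far apart the three lie in this assay, and whether exchanging these groups on the nitrogen changes the result at all.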